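Oxime benzoate amides: working notes on an antiproliferative series

This account rests on a few compounds, and the source may have more. Where it says the series, first, only, none or still open, it means among the compounds named here.

Measured so far:
Compound 1, `CC1(C)C/C(=N\OC(=O)c2ccccc2NC(=O)c2ccccc2F)c2c(-c3ccc(F)cc3)noc2C1`: in a functional assay on HCC1954 cells (Homo sapiens) for antiproliferative activity, read by MTT assay, with a stated time of 72 h (on this read-out lower numbers stand for stronger inhibition and higher numbers for weaker inhibition), compound 1 is recorded only as the limit > 25000 nM.
Compound 2, `O=C(Nc1cccc(C(=O)O/N=C2\CCCc3onc(-c4cccc(F)c4)c32)c1)c1cccc(F)c1`: in this assay compound 2 is recorded only as the limit > 25000 nM.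
Compound 3, `CC1(C)C/C(=N\OC(=O)c2cccc(NC(=O)c3cccc(F)c3)c2)c2c(noc2-c2cccc(F)c2)C1`: in this assay compound 3 is recorded only as the limit > 25000 nM.

None of the three values is a number; each is a limit of the assay. Compound 2 thus stands with the other two at the limit of > 25000 nM in this assay, at which 3 of the 3 values shown sit, and no order among them can be drawn from what is shown. Within the data shown here, no step between measured compounds that differ in a single place is available, so nothing here tells how any one change moves this read-out.

Compound 4, `COc1ccc(-c2noc3c2/C(=N/OC(=O)c2cccc(NC(=O)c4cccc(F)c4)c2)CCC3)cc1OC`, differs from compound 2 by 3,4-dimethoxyphenyl in place of 3-fluorophenyl on an aromatic carbon. Among the measured compounds shown here, with no measured step to lean on, the expected size of this step is none beyond the usual scatter, in either direction. Compound 4 is therefore expected to be reported again at the limit, with an estimate of 25000 nM and a range from 5000 nM to 100000 nM. The step expected is a number no higher from compound 2 to compound 4 (the limit leaves the size open).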

Compound 4, half-maximal inhibitory concentration: > 25000 nM
Compound 4 gave a limit, no number (the forecaster's own chance of this, stated with the estimate: 75%); the middle value lies on the limit itself.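

Compound 2 and compound 4 are both recorded only as limits in this assay, and no step can be read between them. The compounds shown leave open any order among them and how any single change moves the read-out: the limit of > 25000 nM in this assay, at which 4 of the 4 values shown sit.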